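A few compounds are considered here, and "the series" means these few. Any claim that something is new, unique, unknown or untested is made for them only; others in the source may bear on it.

Three measured members of this series share one core, each carrying an amine-bearing chain on one side and a bicyclic amine on the other. Compound 1 `NCC(O)CNc1cc(N2Cc3ccccc3C2)nc2ccccc12` holds the smaller bicyclic amine and a chain with a hydroxyl; in an ADME assay on HEp-2 cells (Homo sapiens) for cytotoxicity, read by CCK-8 assay, with a stated time of 5 days (on this read-out lower numbers stand for higher toxicity in this test and higher numbers for lower toxicity in this test), compound 1 gives 2900 nM. Compound 2 `NCC(O)CNc1cc(N2CCCc3ccccc3C2)nc2ccccc12` widens the bicyclic amine by one ring member, and in this assay compound 2 gives 21000 nM. Compound 3 `NCCNc1cc(N2CCCc3ccccc3C2)nc2ccc(Cl)cc12` keeps that wider amine, carries a chain without the hydroxyl, and adds a chloro group to the core. In this assay compound 3 reaches only a limit of the assay, > 3200 nM, so compound 3 stands as a limit and not as a number among the values shown; that is the limit of > 3200 nM in this assay, at which 1 of the 3 values shown sits. Going by the values given here, no two of the measured compounds differ in a single place, so no measured step guides the next change.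

Compound 4 `NCCNc1cc(N2CCCc3ccccc3C2)nc2ccc(F)cc12` differs from compound 3 by fluoro in place of chloro on an aromatic carbon. For a change of this kind, no shift in this assay beyond the ordinary scatter is expected, in either direction. The expected step from compound 3 to compound 4 is a step that the limit leaves unreadable from compound 3 to compound 4. Compound 4 is therefore estimated at 12000 nM, with a range from 3500 nM to 40000 nM.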

Compound 4, half-maximal cytotoxic concentration: 8000 nM
For compound 4 the middle estimate is 1.5-fold (0.18 log units) above the measured one; measured number inside the range.
By their numbers in this assay, from the lowest: compound 1; then compound 4; then compound 2.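

The step from compound 3 to compound 4 cannot be read in this assay, because compound 3 stands only as a limit: the limit of > 3200 nM in this assay, at which 1 of the 4 values shown sits.

The compounds shown leave open how fluoro and chloro compare as numbers on the shared core, and what the chain hydroxyl or the wider bicyclic amine does on its own.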